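Methyl in Place of Hydrogen on an Amine Nitrogen

The source may hold more compounds than are shown below. What is called first, only, known or untested is meant among the compounds shown, and "the series" means these compounds.

Compound 2 `NC[C@@H]1CCCc2cc(S(=O)(=O)c3cc[nH]c3)ccc21` gives 0.316 nM in an assay on isolated protein for displacement of a labelled ligand from 5-hydroxytryptamine receptor 6 (Homo sapiens); on this read-out lower numbers stand for stronger inhibition and higher numbers for weaker inhibition. Among the measured compounds shown here, its only measured companion is compound 1 `NC[C@@H]1CCCc2cc(S(=O)(=O)c3cccc(O)c3)ccc21`, which in this assay gives 0.251 nM; the step of a 1.3-fold higher number from compound 1 to compound 2 (0.10 log units; within the scatter) is within the scatter, so compound 2 stands beside compound 1 rather than apart from it, the two numbers being indistinguishable on this read-out.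

Compound 3 `CNC[C@@H]1CCCc2cc(S(=O)(=O)c3cc[nH]c3)ccc21` differs from compound 2 by methyl in place of hydrogen on an amine nitrogen. For the measured compounds named here, none of the measured steps bears on this position: the single step, from compound 1 to compound 2, exchanges the group on the sulfonyl sulfur and leaves the amine untouched, so the data hold no precedent for what a methyl on that nitrogen does here. With no anchor, the expectation is a step of modest size at most, and the direction is open; a somewhat higher number is taken as the slightly likelier outcome, the step expected to be a 1.9-fold higher number from compound 2 to compound 3 (0.28 log units; within the scatter). Compound 3 is therefore expected to give about 0.6 nM in this assay, within a range from 0.2 nM to 2 nM.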

Compound 3, inhibition constant: 0.159 nM
Estimate against measurement, compound 3: 3.8-fold (0.58 log units) above; measured number below the stated range.
By their numbers in this assay, from the lowest: compounds 3, 1 and 2 (each within the scatter of the next).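

The methyl on the amine nitrogen is the first change at this position among the compounds shown, and in this assay the step is a 2.0-fold lower number from compound 2 to compound 3 (0.30 log units; within the scatter) and so does not separate the two compounds. Among the compounds shown here, the earlier compounds showed only that the group on the sulfonyl sulfur could be exchanged with the numbers staying within the scatter; this result adds that aminomethyl can become (methylamino)methyl with the same outcome, so the amine nitrogen also accepts a methyl in place of a hydrogen on this read-out. Nothing measured here explains this outcome at the nitrogen, and no reason for it is offered.

The compounds shown leave open whether an ethyl group on this nitrogen, or a second methyl giving a dimethylamino group, would also stay within the scatter of compound 2. For the compounds shown here, also open is whether the same methyl would give a comparable step with 3-hydroxyphenyl on the sulfonyl sulfur, as in compound 1, since the only reading of this change carries 1H-pyrrol-3-yl there.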